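Aza Swap on the Tetrahydroisoquinoline Arm of Compound 2

A few compounds are considered here, and "the series" means these few. Any claim that something is new, unique, unknown or untested is made for them only; others in the source may bear on it.

Compound 1 `c1ccc2c(c1)CN[C@@H](CN(CC1CCNCC1)[C@H]1CCCc3cccnc31)C2`: 65 nM
Compound 2 `c1ccc2c(c1)CN[C@H](CN(CCCN1CCNCC1)[C@H]1CCCc3cccnc31)C2`: 1150 nM
Compound 3 `c1ccc2c(c1)CN[C@@H](CN(CC[C@@H]1CCCNC1)[C@H]1CCCc3cccnc31)C2`: 161 nM

In a functional assay on CCRF-CEM cells for antagonist activity at C-X-C chemokine receptor type 4 (Homo sapiens), read by calcium flux, with stated times of 25 min and 90 s (a higher number here means a weaker inhibitor, a lower number a stronger inhibitor), compound 2 gives 1150 nM, the highest of the three numbers; compound 3 gives 161 nM and compound 1 gives 65 nM, and both gaps to compound 2 lie beyond the scatter. Compound 4 `c1cnc2c(c1)CN[C@@H](CN(CCCN1CCNCC1)[C@H]1CCCc3cccnc31)C2` differs from compound 2 by a group of 10 heavy atoms (8 carbon, 2 nitrogen; one six-membered non-aromatic ring with 1 hetero atom, one six-membered aromatic ring with 1 hetero atom) in place of a group of 10 heavy atoms (9 carbon, 1 nitrogen; one six-membered non-aromatic ring with 1 hetero atom, one six-membered aromatic ring of carbon only), on a saturated chain carbon bound to an amine nitrogen. Among the compounds with values here, the only measured step, a 2.5-fold higher number from compound 1 to compound 3 (0.39 log units; beyond the scatter), concerns the piperidin-4-yl group and not the tetrahydroisoquinolin-3-yl group, so no measured pair speaks to this change. Lacking such a precedent, compound 4 is expected to stay near compound 2, with a step of no change at the digits printed from compound 2 to compound 4 (within the scatter), none beyond the scatter. The estimate for compound 4 is 1150 nM, within 400 nM to 3500 nM.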

Compound 4, half-maximal inhibitory concentration: 171 nM
Compound 4: the middle estimate sits 6.7-fold (0.83 log units) above what was measured; measured number outside the range, below it.
By their numbers in this assay, from the lowest: compound 1; then compounds 3 and 4 (each within the scatter of the next); then compound 2.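

Putting a nitrogen into the carbon-only aromatic ring of the 1,2,3,4-tetrahydroisoquinolin-3-yl group gives, in this assay, a 6.7-fold lower number from compound 2 to compound 4 (0.83 log units; beyond the scatter) and shows that this group, on a saturated chain carbon bound to an amine nitrogen, is not indifferent to the swap. Within the data shown here, until now, the only measured step concerned the piperidin-4-yl group. Nothing measured here explains the step.

As far as these compounds go, whether a nitrogen elsewhere in that ring, or a fluorine or methoxy group on it, would act alike remains open. So does whether this swap would carry over to the piperidin-4-yl side chain of compound 1.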